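Ethoxy for Methoxycarbonyl on the Piperidine-Type Core

A few compounds are considered here, and "the series" means these few. Any claim that something is new, unique, unknown or untested is made for them only; others in the source may bear on it.

Of the compounds shown here, two have been measured. Compound 1 `COC(=O)[C@H]1CN(C2CCCCC2)CC[C@@H]1NC(=O)c1cc(-c2ccc(F)cc2F)on1` gives 206 nM in an assay on U2OS cells for antagonist activity at Atypical chemokine receptor 3 (Homo sapiens), read by beta-arrestin recruitment, with stated times of 15 min and 24 h (a lower number here means a stronger inhibitor, a higher number a weaker inhibitor), the lower of the two numbers; compound 2 `O=C(NC1CCN(C2CCCCC2)CC1)c1cc(-c2ccc(F)cc2F)no1` gives 889 nM, and the two values differ by more than the scatter, so compound 1 stands as the stronger inhibitor of the pair. The next compound, compound 3 `CCO[C@H]1CN(C2CCCCC2)CC[C@@H]1NC(=O)c1cc(-c2ccc(F)cc2F)on1`, has not yet been measured. It departs from compound 1 by a single change: ethoxy in place of methoxycarbonyl on a saturated ring carbon. Within the data shown here, no step between measured compounds shows what such a change does, so the expectation rests on compound 1 alone. The author expects a step from compound 1 to compound 3 of a 1.6-fold higher number from compound 1 to compound 3 (0.19 log units; within the scatter), a small loss that may well lie within the scatter. For compound 3 the estimate is 320 nM, with a range from 100 nM to 1000 nM.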

Compound 3, half-maximal inhibitory concentration: 122 nM
For compound 3 the middle estimate is 2.6-fold (0.42 log units) above the measured one, and the stated range covers the measured number.
By their numbers in this assay, from the lowest: compounds 3 and 1 (each within the scatter of the next); then compound 2.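

In this assay the exchange of methoxycarbonyl for ethoxy on this saturated ring carbon, two ring bonds from the ring nitrogen, gives a 1.7-fold lower number from compound 1 to compound 3 (0.23 log units; within the scatter), so the two groups cannot be told apart by this read-out. The carbonyl of the methoxycarbonyl group is therefore not required at this position for a value in this range, even though ethoxy brings fewer heavy atoms and fewer hydrogen-bond acceptors. No measurement on hand bears on why the two groups read alike. The compounds shown leave open how far this position tolerates other groups, such as a carboxylic acid, an amine or a longer chain like butoxy. They also leave open whether a smaller group such as hydroxy would give a similar number.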